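A Methyl Step Between Two Assay Limits

A few compounds are considered here, and "the series" means these few. Any claim that something is new, unique, unknown or untested is made for them only; others in the source may bear on it.

Three compounds were tested in a functional assay on HeLa cells (Homo sapiens) for inhibition, read by MTT assay, with a stated time of 48 h (on this read-out higher numbers stand for weaker inhibition and lower numbers for stronger inhibition), and a fourth awaits measurement. Compound 1 `O=C1CN(C2CCCC2)c2nc(Nc3ccc(N4CCCCC4)cc3)ncc2N1` and compound 2 `CC1CCN(c2ccc(Nc3ncc4c(n3)N(C3CCCC3)CC(=O)N4)cc2)CC1` share one core, and compound 2 differs from compound 1 by methyl in place of hydrogen on a saturated ring carbon. In this assay compound 1 gives only a limit, > 30000 nM. Compound 2 likewise gives only a limit, > 30000 nM. The step that the two limits leave unreadable from compound 1 to compound 2 cannot be read because both values sit at the limit of > 30000 nM in this assay, at which 3 of the 3 values shown sit.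

Compound 3 `CN1C(=O)CN(C2CCCC2)c2nc(Nc3ccc(N4CCCCC4)cn3)ncc21` carries a different core; the difference between the two cores is not broken down here. In this assay compound 3 also gives only a limit, > 30000 nM.

Compound 4 `CC1CCN(c2ccc(Nc3ncc4c(n3)N(C3CCCC3)CC(=O)N4C)nc2)CC1` differs from compound 3 by methyl in place of hydrogen on a saturated ring carbon, the same change as that made from compound 1 to compound 2, at a place described in the same words. The expected step is a step that the limit leaves unreadable from compound 3 to compound 4, which rests on the step that the two limits leave unreadable from compound 1 to compound 2 having left both compounds at the limit. Compound 4 is therefore expected to give about 50000 nM. The expected range for compound 4 runs from 25000 nM to 100000 nM, most likely reported as a limit again.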

Compound 4, half-maximal inhibitory concentration: > 30000 nM
Compound 4: a limit, no number; the forecaster's own chance of this, stated with the estimate: 85%; the middle value does not contradict the limit.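

No new step can be read from compound 3 to compound 4 in this assay, where compound 4, like compound 3, gives only a limit: the limit of > 30000 nM in this assay, at which 4 of the 4 values shown sit.

The compounds shown leave open whether the change from piperidin-1-yl to 4-methylpiperidin-1-yl alters inhibition at all, and how strongly any of the four compounds inhibits in this assay.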